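Isopropyl on the ring amide nitrogen of compound 1

The source may hold more compounds than are shown below. What is called first, only, known or untested is meant among the compounds shown, and "the series" means these compounds.

Measured compounds:
Compound 1 `O=C1COc2ccc(-c3cccc(NS(=O)(=O)c4ccc(F)cc4)c3)cc2N1`: 20100 nM
Compound 2 `COc1ncc(-c2ccc3c(c2)N(c2ccccc2)C(=O)CO3)cc1NS(=O)(=O)c1ccc(F)cc1`: 15200 nM

In a functional assay on A-375 cells (Homo sapiens) for antiproliferative activity, read by MTT assay, with a stated time of 72 h (on this read-out higher numbers stand for weaker inhibition and lower numbers for stronger inhibition), compound 1 gives 20100 nM and compound 2 gives 15200 nM. Within the data shown here, these two numbers lie within the scatter of each other, so compound 1 stands together with the only other measured compound.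

Compound 3 `CC(C)N1C(=O)COc2ccc(-c3cccc(NS(=O)(=O)c4ccc(F)cc4)c3)cc21` keeps the core of compound 1 and alters it in one place: isopropyl in place of hydrogen on an amide-type nitrogen in a ring. This puts isopropyl in place of hydrogen on an amide-type nitrogen in a ring. Among the measured compounds shown here, no measured pair isolates this change, so the data give no direct guide to it. In this assay only a small step towards a lower number is expected, hardly beyond the scatter. The expected change is a 1.5-fold lower number from compound 1 to compound 3 (0.19 log units; within the scatter). Compound 3 is estimated at 13000 nM, with an expected range from 4500 nM to 35000 nM.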

Compound 3, half-maximal inhibitory concentration: > 40000 nM
Compound 3: a limit, no number (the forecaster's own chance of this, stated with the estimate: 12%); middle value at least 3.0-fold (0.48 log units) from the limit.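

Among these compounds, with isopropyl in place of hydrogen on the amide-type nitrogen in the ring, the series gains its first direct reading at this position: in this assay the change gives an at least 1.9-fold higher number from compound 1 to compound 3 (0.29 log units; that floor lies within the scatter) and shows no step towards a lower number. That step is only a floor, as compound 3 carries a limit of the assay and not a number: the limit of > 40000 nM in this assay, at which 1 of the 3 values shown sits. On these data alone, the true size of the step therefore stays unknown, and the floor alone does not clear the scatter.

The compounds shown leave open how a methyl group, or a longer chain ending in an amine or a carboxylic acid, would read on this nitrogen. They also leave open whether any such group would give a number rather than a limit in this assay.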